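From Cyclohexylamino to Pyrrolidin-1-yl on a Carbonyl Carbon

The source may hold more compounds than are shown below. What is called first, only, known or untested is meant among the compounds shown, and "the series" means these compounds.

In a functional assay on BXPC-3 cells (Homo sapiens) for cytotoxicity, read by fluorescence, with a stated time of 48 h (a lower number here means that less compound is needed, a higher number that more compound is needed for the effect), compound 1 (`CC(C)=CCC/C(C)=C/CC/C(C)=C/CSC[C@H](NC(=O)CCCCCN1CCCC1)C(=O)NC1CCCCC1`) gives 12700 nM. Compound 2 (`CC(C)=CCC/C(C)=C/CC/C(C)=C/CSC[C@H](NC(=O)CCCCCN1CCN(C)CC1)C(=O)NC1CCCCCCC1`) gives 7500 nM. Going by the values given here, these two numbers lie within the scatter of each other, so compound 1 stands level with the only other measured compound, and neither can be ranked above the other.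

Compound 3 (`CC(C)=CCC/C(C)=C/CC/C(C)=C/CSC[C@H](NC(=O)CCCCCN1CCCC1)C(=O)N1CCCC1`) has not yet been measured. It carries pyrrolidin-1-yl in place of cyclohexylamino on a carbonyl carbon. Among the compounds with values here, no measured pair shows this change alone, so the forecast is uncertain. Starting from compound 1 at 12700 nM, a modest move toward a higher number is expected, meaning that somewhat more compound would be needed. The estimated step is a 1.6-fold higher number from compound 1 to compound 3 (0.20 log units; within the scatter), which would remain within the usual scatter. For compound 3, the estimated value is 20000 nM, with an expected range of 8000 nM to 50000 nM.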

Compound 3, half-maximal effective concentration: 6500 nM
Beside the measured number, compound 3's estimate is 3.1-fold (0.49 log units) above it; the whole stated range lies above it.
By their numbers in this assay, from the lowest: compounds 3, 2 and 1 (each within the scatter of the next).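

Read alone at this carbonyl carbon, for the first time, the change in this assay gives a 2.0-fold lower number from compound 1 to compound 3 (0.29 log units; within the scatter) and does not separate the two compounds. Cyclohexylamino, with its six-membered carbon ring and hydrogen-bond donor, can therefore give way to pyrrolidin-1-yl, which has no hydrogen-bond donor, while the number stays within the scatter. No measured evidence offers an explanation for this result.

The swap changes the ring and removes the amide hydrogen together, so this single step cannot show what either change does alone. Also unresolved is whether another group here, such as piperidin-1-yl, morpholin-4-yl or an open-chain dimethylamino, would give a number beyond the scatter from compound 1.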